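A few compounds are considered here, and "the series" means these few. Any claim that something is new, unique, unknown or untested is made for them only; others in the source may bear on it.

Compounds measured so far:
compound 1 `Cc1ccc(O)c(CNc2ccc(C3CCCCC3)cc2)c1` — "not active" (no number reported)
compound 2 `Oc1ccccc1CNc1ccc(N2CCNCC2)cc1` — "not active" (no number reported)
compound 3 `Oc1ccccc1CNc1ccc(-c2ccccc2)cc1` — 1820 nM

Going by the values given here, in a functional assay on Jurkat cells (Homo sapiens) for activation, with a stated time of 24 h (a higher number here means that more compound is needed for the effect, a lower number that less compound is needed), compound 3 gives 1820 nM, the only number the set holds; compound 1 and compound 2 are reported without a number. Compound 4 `N#Cc1ccc(-c2ccc(NCc3ccccc3O)cc2)cc1` is not yet measured. It differs from compound 3 by cyano in place of hydrogen on an aromatic carbon. Among the compounds with values here, no measured pair shows what this change does, so its effect in this assay is unknown. Given that the shared core of compound 3 carries the only activity seen here, compound 4 is expected to stay close to it, with a step of a 1.5-fold lower number from compound 3 to compound 4 (0.18 log units; within the scatter) that lies near the scatter and leans towards less compound needed. Compound 4 is therefore estimated at 1200 nM, within a range of 300 nM to 5000 nM.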

Compound 4, half-maximal effective concentration: "not active" (no number reported)
For compound 4 the study gives words and no number; no gap can be computed for the estimate.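

In this assay, going by these compounds alone, compound 4 is reported in words only, so no step from compound 3 can be read, and no supporting data bear on this result. The compounds shown leave open what cyano in place of hydrogen does to the value.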